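The source may hold more compounds than are shown below. What is called first, only, known or untested is meant among the compounds shown, and "the series" means these compounds.

Of the compounds shown here, three have been measured in an ADME assay for permeability, using PAMPA, at pH 7.4 (on this read-out lower numbers stand for lower permeability and higher numbers for higher permeability), and they span a wide range. Compound 1 (`O=C(O)COc1cc(Cl)c(C(=O)Nc2cccc(-c3nc4ccccc4s3)c2)cc1[N+](=O)[O-]`) gives < 1 10^-6 cm/s, which is a limit of the assay and not a number. Compound 2 (`O=C(Nc1nc2c(Cl)cccc2s1)c1cc([N+](=O)[O-])ccc1Cl`) gives 242 10^-6 cm/s. Compound 3 (`Cc1cc(NC(=O)c2cc([N+](=O)[O-])ccc2Cl)cc(-c2nc3ccccc3o2)c1O`) gives 105 10^-6 cm/s, the lower of the two real numbers, and its gap to compound 2 is beyond the usual scatter of repeat measurements.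

The next structure, compound 4 (`Cc1cc(NC(=O)c2cc([N+](=O)[O-])ccc2Cl)cc(-c2nc3ccccc3s2)c1O`), keeps everything in compound 3 except one group. It has 1,3-benzothiazol-2-yl in place of 1,3-benzoxazol-2-yl on an aromatic carbon, ortho to a hydroxy group: 1,3-benzothiazol-2-yl in place of 1,3-benzoxazol-2-yl on an aromatic carbon. The two groups are the same size and have the same ring types, and the change is confined to this one place.

Among the compounds with values here, no pair of measured compounds shows this exchange on its own, so there is no direct precedent for its size in this assay. The best guide is therefore the close parent, compound 3 at 105 10^-6 cm/s, and no step beyond the scatter is expected. The estimated step is a 1.1-fold higher number from compound 3 to compound 4 (0.06 log units; within the scatter), a slight rise at most. For compound 4 the expected value is 120 10^-6 cm/s, with an estimated range from 50 10^-6 cm/s to 280 10^-6 cm/s.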

Compound 4, apparent permeability in the ADME assay: 48 10^-6 cm/s
For compound 4 the middle estimate is 2.5-fold (0.40 log units) above the measured one; the measured number lies below the stated range.
By their numbers in the ADME assay, from the lowest: compound 4; then compound 3; then compound 2. At a limit, below all of these: compound 1.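

In the ADME assay the exchange of 1,3-benzoxazol-2-yl for 1,3-benzothiazol-2-yl, on an aromatic carbon ortho to a hydroxy group, gives a 2.2-fold lower number from compound 3 to compound 4 (0.34 log units; beyond the scatter), so the read-out at this position responds to the swap even though the two groups match in heavy-atom number, ring types, hydrogen-bond donors and hydrogen-bond acceptors. In a physicochemical assay for solubility, read by spectrophotometry, in phosphate buffer, measured as kinetic solubility, with a stated time of 18 h, at pH 7.4 (a lower number here means a less soluble compound, a higher number a more soluble compound), compound 3 gives 90 nM and compound 4 gives 430 nM. In the physicochemical assay the same exchange moves the number the other way, upward instead of downward: the measured solubility of compound 3, 90 nM, and of compound 4, 430 nM, a 4.8-fold higher number (0.68 log units; beyond the scatter) Read together, the two read-outs do not travel in the same direction for this one pair, which is a single observation and sets no general rule for other compounds.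

From the compounds shown here alone, whether the exchange would have the same size and direction on a parent without the hydroxy group remains open, as compound 1 and compound 2 each differ from compound 3 and compound 4 in more than one place. Also open, going by these compounds, is how either read-out would respond to quite a different group on this aromatic carbon, such as a plain phenyl ring or an amine.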